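This account rests on a few compounds, and the source may have more. Where it says the series, first, only, none or still open, it means among the compounds named here.

Measured in a functional assay on MCF7 cells (Homo sapiens) for cytotoxicity, read by CCK-8 assay, with a stated time of 72 h; on this read-out higher numbers stand for weaker inhibition and lower numbers for stronger inhibition:
compound 1 `C=CCn1c(=O)/c(=C\c2ccccc2Cl)[nH]c(=O)/c1=C\c1ccccc1OC` gives 4700 nM
compound 2 `C=CCn1c(=O)/c(=C\c2ccccc2OC)[nH]c(=O)/c1=C\c1ccccc1OC` gives 41100 nM
compound 3 `C=CCn1c(=O)/c(=C\c2ccccc2C(F)(F)F)[nH]c(=O)/c1=C\c1ccccc1OC` gives 6500 nM

Compound 3 sits second highest of the three numbers. Its nearest neighbour is compound 1, the pair showing a 1.4-fold higher number from compound 1 to compound 3 (0.14 log units; within the scatter); its furthest is compound 2, the pair showing a 6.3-fold lower number from compound 2 to compound 3 (0.80 log units; beyond the scatter).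

Compound 4 `C=CCn1c(=O)/c(=C\c2ccc(C)cc2)[nH]c(=O)/c1=C\c1ccccc1OC` differs from compound 3 by 4-methylphenyl in place of 2-(trifluoromethyl)phenyl on a double-bonded chain carbon bound to an aromatic carbon. Among the compounds with values here, no measured step replaces this whole ring; the measured steps only exchange a single substituent on it: an 8.7-fold higher number from compound 1 to compound 2 (0.94 log units; beyond the scatter), a 1.4-fold higher number from compound 1 to compound 3 (0.14 log units; within the scatter) and a 6.3-fold lower number from compound 2 to compound 3 (0.80 log units; beyond the scatter). Within the data shown here, these show that changes at this ring move the number at most modestly, and the new ring has no measured precedent here. For compound 4 the expected step is therefore a 1.2-fold higher number from compound 3 to compound 4 (0.09 log units; within the scatter), with no move beyond the scatter expected. The estimate for compound 4 is 8000 nM, range 2500 nM to 30000 nM.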

Compound 4, half-maximal inhibitory concentration: "not active" (no number reported)
Compound 4 has no reported number here, so the estimate cannot be set against anything.
By their numbers in this assay, from the lowest: compounds 1 and 3 (each within the scatter of the next); then compound 2.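

Within the data shown here, compound 4 is reported as "not active" without a number in this assay, so no step linking it to compound 3 or any other compound can be read. No evidence bears on this result. From the compounds shown here alone, how far 4-methylphenyl in place of 2-(trifluoromethyl)phenyl moves the number stays open.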